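The compounds below may be only part of what the source reports. "The series", "measured", "known", "first", "only" and "open" are said of these compounds alone.

The measured compounds are:
compound 1, `C=CC(=O)Nc1cccc(NC(=O)CSc2nc(Nc3ccccc3Cl)c3ccccc3n2)c1`, which in a functional assay on PC-3 cells (Homo sapiens) for inhibition, read by MTT assay, with a stated time of 72 h (a lower number here means a stronger inhibitor, a higher number a weaker inhibitor), gives 14400 nM;
compound 2, `C=CC(=O)Nc1cccc(NC(=O)CSc2nc(Nc3cccc(C)c3)c3ccccc3n2)c1`, which in this assay gives 29200 nM.

Of these two numbers, compound 2 stands highest. Within the data shown here, the only measured step, a 2.0-fold higher number from compound 1 to compound 2 (0.31 log units; beyond the scatter), is modest but lies beyond the scatter, so compound 2 is the weaker of the two inhibitors in this small set.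

Compound 3, `C=CC(=O)Nc1cccc(NC(=O)CSc2nc(Nc3cccc(OC)c3)c3ccccc3n2)c1`, is reached from compound 2 by methoxy in place of methyl on an aromatic carbon. Among the measured compounds shown here, no measured step bears directly on this exchange: the single known step, a 2.0-fold higher number from compound 1 to compound 2 (0.31 log units; beyond the scatter), concerns the swap of one whole aryl group for another, not methyl against methoxy, and nothing in the two measured compounds separates those two groups. For the measured compounds named here, with no comparable step to lean on, the change is expected to leave the read-out in this assay near where compound 2 sits. Compound 3 is therefore estimated at 26000 nM, with a range from 9000 nM to 70000 nM. For compound 3 the implied step, a 1.1-fold lower number from compound 2 to compound 3 (0.05 log units; within the scatter), is expected to remain within the usual scatter.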

Compound 3, half-maximal inhibitory concentration: 34900 nM
Beside the measured number, compound 3's estimate is 1.3-fold (0.13 log units) below it; the range from low to high includes it.
By their numbers in this assay, from the lowest: compound 1; then compounds 2 and 3 (each within the scatter of the next).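

The exchange of methyl for methoxy on this aromatic carbon gives a 1.2-fold higher number from compound 2 to compound 3 (0.08 log units; within the scatter) in this assay and so shows that, in this one pair, the oxygen brought in by methoxy leaves the read-out indistinguishable from that of compound 2. The exchange of the whole aryl group now has a second reading: replacing 2-chlorophenyl with 3-methoxyphenyl gives a 2.4-fold higher number from compound 1 to compound 3 (0.38 log units; beyond the scatter) and is, like the earlier exchange that gave a 2.0-fold higher number from compound 1 to compound 2 (0.31 log units; beyond the scatter), modest but beyond the scatter, which leaves compound 1 the strongest inhibitor of the three. Nothing at hand explains why these numbers fall as they do.

The compounds shown leave open whether the lower number of compound 1 goes with the chlorine itself or with where it sits on the ring, which 3-chlorophenyl or 2-methylphenyl on the same nitrogen would help to separate. They also leave open whether a group of another kind on this aromatic carbon, such as an amine or a carboxylic acid, would move the number beyond the scatter of compound 2 and compound 3.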